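The source may report more compounds than this note shows. Statements on the series, on what has been measured and on what is new or still open speak of the compounds shown alone.

Measured so far:
compound 1 `C[C@H]1[C@H](NCc2cncnc2)C[C@H]2C[C@@H]1C2(C)C` — > 100000 nM
compound 2 `C=Cc1ccsc1CN[C@@H]1C[C@H]2C[C@@H]([C@H]1C)C2(C)C` — 50000 nM
compound 3 `C[C@H]1[C@H](NCc2cc(C3CC3)cs2)C[C@H]2C[C@@H]1C2(C)C` — 25000 nM

In an ADME assay on MDCK cells (Canis lupus familiaris) for cytotoxicity, read by microscopy, with a stated time of 48 h (a lower number here means that less compound is tolerated, a higher number that more compound is tolerated), compound 1 gives only a limit, > 100000 nM, which is the limit of > 100000 nM in this assay, at which 1 of the 3 values shown sits. Compound 2 gives 50000 nM in this assay, and compound 3 gives 25000 nM; the two numbers lie within the scatter of each other, so neither can be set apart from the other. Compound 4 `C=Cc1csc(CN[C@@H]2C[C@H]3C[C@@H]([C@H]2C)C3(C)C)c1` is not yet measured. It differs from compound 3 by vinyl in place of cyclopropyl on an aromatic carbon. Among the measured compounds shown here, no measured pair shows what this change does, so no step beyond the scatter is expected in this assay. For compound 4 the estimate is 40000 nM, with a range from 15000 nM to 100000 nM. This estimate means a step of a 1.6-fold higher number from compound 3 to compound 4 (0.20 log units; within the scatter) is expected.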

Compound 4, minimum cytotoxic concentration: 6250 nM
Compound 4: middle estimate off by 6.4-fold (0.81 log units), on the high side; the measured number lies below the stated range.
By their numbers in this assay, from the lowest: compound 4; then compounds 3 and 2 (each within the scatter of the next). At a limit, above all of these: compound 1.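

In this assay, among the compounds shown here, the change from cyclopropyl to vinyl, on the aromatic carbon two ring bonds from the ring sulfur, gives a 4.0-fold lower number from compound 3 to compound 4 (0.60 log units; beyond the scatter), the first step that lies beyond the scatter. The group on this carbon therefore affects how much compound the cells tolerate, even in a change this small. Nothing measured here gives a reason for the step.

For the compounds shown here, whether the step follows the double bond or the loss of the ring remains open, with only this one pair at this position. An ethyl group or an amine on the same carbon would help separate the two.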